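The compounds below may be only part of what the source reports. "The series", "measured", "known", "first", "only" and "open" are said of these compounds alone.

Working notes on the diaryl urea series.

Compound 1 `COc1cc2cc(Oc3ccc(NC(=O)Nc4ccccc4)cc3)c(C)nc2cc1OC` is the unsubstituted parent; in a functional assay on IGROV-1 cells (Homo sapiens) for inhibition, read by sulforhodamine B assay, with a stated time of 48 h, tested at 10 uM (on this read-out lower numbers stand for a stronger effect and higher numbers for a weaker effect at the one concentration tested), compound 1 gives 103%. Compound 2 `COc1cc2cc(Oc3ccc(NC(=O)Nc4ccc(C(F)(F)F)cc4)cc3)c(C)nc2cc1OC` carries a trifluoromethyl group and in this assay compound 2 gives 71.9%, a step of a number 31.1 percentage points lower from compound 1 to compound 2 (beyond the scatter). Compound 3 `COc1cc2cc(Oc3ccc(NC(=O)Nc4cccc(C(F)(F)F)c4)cc3)c(C)nc2cc1OC` carries the trifluoromethyl group at the other position; in this assay compound 3 gives 8.77%. Compound 3 stands lowest of the three: the step of a number 94.2 percentage points lower from compound 1 to compound 3 (beyond the scatter) is the largest in the set, and the step of a number 63.1 percentage points lower from compound 2 to compound 3 (beyond the scatter) separates it from its nearest neighbour, compound 2.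

Compound 4 `COc1cc2cc(Oc3ccc(NC(=O)Nc4ccc(Cl)c(C(F)(F)F)c4)cc3)c(C)nc2cc1OC` differs from compound 3 by chloro in place of hydrogen on an aromatic carbon. Within the data shown here, none of the measured steps concerns a chloro group; all three involve a trifluoromethyl group, so no measured step bears directly on this change. Compound 3 already gives a very low read-out, which leaves little room for a further fall. Compound 4 is therefore expected to stay near compound 3, with a step of a number 3.2 percentage points higher from compound 3 to compound 4 (within the scatter) that is estimated to lie within the scatter. The estimate for compound 4 in this assay is 12%, in a range from 0% to 35%.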

Compound 4, a percentage reported as activity, at one concentration (the size of the read-out at that concentration, not a potency): -7.69%
Compound 4: the middle estimate sits 19.7 percentage points above what was measured, and the stated range ends above it.
By their numbers in this assay, from the lowest: compound 4; then compound 3; then compound 2; then compound 1.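

In this assay the step of a number 16.5 percentage points lower from compound 3 to compound 4 (beyond the scatter) shows that chloro on the aromatic carbon ortho to the trifluoromethyl group and para to a large group still lowers the read-out, even from a value already close to zero. With the 4-chloro-3-(trifluoromethyl)phenyl group the distance from the earlier ureas widens, with a number 79.6 percentage points lower from compound 2 to compound 4 (beyond the scatter) and a number 110.7 percentage points lower from compound 1 to compound 4 (beyond the scatter) and compound 4 is the only one of the four with a read-out below zero. Nothing at hand explains why this chloro group lowers the read-out.

As far as these compounds go, whether chloro has the same effect on the phenyl ring without the trifluoromethyl group stays open, as does the outcome with fluoro, bromo, methoxy or an amine at this position. Among these compounds, a read-out at one concentration shows only that compound 4 has a stronger effect than compound 3 at that concentration.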